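Cytotoxicity notes: distal ring variation, compound 2 to compound 3

This account rests on a few compounds, and the source may have more. Where it says the series, first, only, none or still open, it means among the compounds named here.

Measured so far:
compound 1, `Cc1cc(-c2ccccc2)cc(C)c1Oc1cc(N)nc(Nc2ccc(C#N)cc2)n1`: 25600 nM
compound 2, `Cc1cc(-c2ccccc2F)cc(C)c1Oc1cc(N)nc(Nc2ccc(C#N)cc2)n1`: 29300 nM

Both numbers come from a toxicity assay on MT4 cells (Homo sapiens) for cytotoxicity, read by MTT assay; on this read-out higher numbers stand for lower toxicity in this test and lower numbers for higher toxicity in this test. Compound 2 holds the higher of the two numbers, but the step of a 1.1-fold higher number from compound 1 to compound 2 (0.06 log units; within the scatter) lies within the scatter, so the two compounds cannot be told apart on this read-out.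

Compound 3, `Cc1cc(-c2ccc(C#N)c(C#N)c2)cc(C)c1Oc1cc(N)nc(Nc2ccc(C#N)cc2)n1`, has not been measured. It differs from compound 2 by 3,4-dicyanophenyl in place of 2-fluorophenyl on an aromatic carbon. Going by the values given here, the only measured step, a 1.1-fold higher number from compound 1 to compound 2 (0.06 log units; within the scatter), touches the same ring and moved the number by little; no measured step shows a nitrile entering this ring, so the new group is untested here. Among the compounds with values here, the one step available gives no ground to expect a move beyond the scatter. Compound 3 is therefore expected to return about 25000 nM, with a range of 10000 nM to 60000 nM. The expected step is a 1.2-fold lower number from compound 2 to compound 3 (0.07 log units; within the scatter), essentially flat.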

Compound 3, half-maximal cytotoxic concentration: 17600 nM
The estimate for compound 3 lay 1.4-fold (0.15 log units) above the measured number, within the range that was stated.
By their numbers in this assay, from the lowest: compounds 3, 1 and 2 (each within the scatter of the next).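

At the position para to a large group, 3,4-dicyanophenyl can now be compared in this assay with both earlier groups: 2-fluorophenyl (a 1.7-fold lower number from compound 2 to compound 3 (0.22 log units; within the scatter)) and phenyl (a 1.5-fold lower number from compound 1 to compound 3 (0.16 log units; within the scatter)). Both steps lie within the scatter, so the first nitrile-bearing ring in the series, which also adds hydrogen-bond acceptors and more heavy atoms, cannot be told apart from the phenyl or 2-fluorophenyl compounds on this read-out. Nothing available explains this result or bears on it.

Going by these compounds, the three compounds cover only neutral phenyl rings at this position, so it remains open whether an amine or a carboxylic acid on the ring would move the number beyond the scatter. Also open, on these data alone, is whether a longer alkyl chain in place of the ring would leave the number unchanged.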